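The source may report more compounds than this note shows. Statements on the series, on what has been measured and on what is new or still open speak of the compounds shown alone.

The measured compounds and their numbers:
compound 1 `C/N=C(/S)C1=CC(C)(C)Oc2ccc(C(F)(F)C(F)(F)F)cc21`: a functional assay (aorta) with Rattus norvegicus as the target (on this read-out lower numbers stand for an effect already at smaller amounts and higher numbers for an effect only at larger amounts of compound), 12.6 nM
compound 2 `C/N=C(/S)C1=CC(C)(C)Oc2ccc(OC(F)(F)F)cc21`: this assay 4.07 nM
compound 3 `C/N=C(/S)C1=CC(C)(C)Oc2ccc(Br)cc21`: this assay 9.33 nM

Compound 3 stands second highest of the three numbers in this assay; its nearest neighbour is compound 1, from which it differs only within the scatter (a 1.4-fold lower number from compound 1 to compound 3 (0.13 log units; within the scatter)), while compound 2 lies furthest from it (a 2.3-fold higher number from compound 2 to compound 3 (0.36 log units; beyond the scatter)). The step to compound 4 `C/N=C(/S)C1=CC(C)(C)Oc2ccccc21` changes compound 3 in one place: hydrogen in place of bromo on an aromatic carbon.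

Among the compounds with values here, no measured step removes a substituent from this aromatic carbon altogether; the three known steps only exchange one group for another. They show that the identity of the group at this position matters, but only modestly: a 3.1-fold lower number from compound 1 to compound 2 (0.49 log units; beyond the scatter), a 2.3-fold higher number from compound 2 to compound 3 (0.36 log units; beyond the scatter), and a 1.4-fold lower number from compound 1 to compound 3 (0.13 log units; within the scatter). Taking the bromo away entirely is a different kind of change from any of these, so the direction rests on weak ground. On balance a somewhat higher number, beyond the scatter, is expected for compound 4, meaning a step of a 3.2-fold higher number from compound 3 to compound 4 (0.51 log units; beyond the scatter). Compound 4 is therefore estimated at 30 nM in this assay, with a range from 8 nM to 120 nM.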

Compound 4, half-maximal effective concentration: 4270 nM
Compound 4: the middle estimate sits 140-fold (2.15 log units) below what was measured, outside the stated range (above it).
By their numbers in this assay, from the lowest: compound 2; then compounds 3 and 1 (each within the scatter of the next); then compound 4.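

Having a group on this aromatic carbon at all matters far more than which of the three groups it is. In this assay, hydrogen in place of bromo gives a large change (a 460-fold higher number from compound 3 to compound 4 (2.66 log units; beyond the scatter)), as does hydrogen in place of trifluoromethoxy (a 1000-fold higher number from compound 2 to compound 4 (3.02 log units; beyond the scatter)) and hydrogen in place of 1,1,2,2,2-pentafluoroethyl (a 340-fold higher number from compound 1 to compound 4 (2.53 log units; beyond the scatter)), whereas the largest exchange among the three groups themselves is far smaller (a 3.1-fold lower number from compound 1 to compound 2 (0.49 log units; beyond the scatter)). The data offer no measured property or other finding that would explain this dependence on a substituent.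

The compounds shown leave open whether a fluoro, a chloro or a methyl on this carbon would keep numbers close to those of compound 1, compound 2 and compound 3, or whether part of the loss seen with compound 4 would remain. They also leave open how an amine, a carboxylic acid or a longer alkyl chain would behave at the same place, since the three groups compared here cover only a narrow set of halogen and fluorinated substituents.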